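This account rests on a few compounds, and the source may have more. Where it says the series, first, only, none or still open, it means among the compounds named here.

Compound 1 `Cc1ccnc(-c2cnc(C(=O)CCCCCCc3ccccc3)o2)c1` gives 0.6 nM in an assay (Rattus norvegicus) for inhibition of Fatty-acid amide hydrolase 1 (Homo sapiens); a higher number here means a weaker inhibitor, a lower number a stronger inhibitor.
Compound 2 `NC(=O)c1cccc(-c2cnc(C(=O)CCCCCCc3ccccc3)o2)n1` gives 1 nM in this assay.
Compound 3 `O=C(CCCCCCc1ccccc1)c1ncc(-c2ncccn2)o1` gives 5.3 nM in this assay.

Compound 3 has the highest number of the three; the steps that lead to it are an 8.8-fold higher number from compound 1 to compound 3 (0.95 log units; beyond the scatter) and a 5.3-fold higher number from compound 2 to compound 3 (0.72 log units; beyond the scatter), both beyond the scatter. Compound 4 `O=C(CCCCCCc1ccccc1)c1ncc(-c2cncnc2)o1` differs from compound 3 by pyrimidin-5-yl in place of pyrimidin-2-yl on an aromatic carbon. Within the data shown here, no measured step makes this same change, so its effect is unknown; the only steps that touch this place, an 8.8-fold higher number from compound 1 to compound 3 (0.95 log units; beyond the scatter) and a 5.3-fold higher number from compound 2 to compound 3 (0.72 log units; beyond the scatter), were modest, which suggests a change of the group here moves this assay by a modest step at most, in either direction. For compound 4 the estimate is 10 nM, with a range from 2 nM to 50 nM. This estimate means an expected step of a 1.9-fold higher number from compound 3 to compound 4 (0.28 log units; within the scatter).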

Compound 4, inhibition constant: 22 nM
Beside the measured number, compound 4's estimate is 2.2-fold (0.34 log units) below it; measured number inside the range.
By their numbers in this assay, from the lowest: compounds 1 and 2 (each within the scatter of the next); then compound 3; then compound 4.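

In this assay, swapping pyrimidin-2-yl for pyrimidin-5-yl keeps the same atoms, joined differently, yet gives a 4.2-fold higher number from compound 3 to compound 4 (0.62 log units; beyond the scatter) here, so how the ring is joined matters at this place and not only what it contains. The pyridine-bearing compounds sit further off, with a 22-fold higher number from compound 2 to compound 4 (1.34 log units; beyond the scatter) and a 37-fold higher number from compound 1 to compound 4 (1.56 log units; beyond the scatter) as large steps, so this place allows bigger moves than the earlier modest steps showed. No measurement here accounts for these differences. Open, going by these compounds, is whether an amine on the pyrimidin-5-yl ring would recover the lost ground, and whether pyrimidin-4-yl behaves like either isomer.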